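This account rests on a few compounds, and the source may have more. Where it says the series, first, only, none or still open, it means among the compounds named here.

Measured compounds:
compound 1 `CC1=CC[C@@H]([C@@](C)(O)CCCC(C)(C)NC(=S)N/N=C\c2cccc([N+](=O)[O-])c2)CC1` — 7840 nM
compound 2 `CC1=CC[C@@H]([C@@](C)(O)CCCC(C)(C)NC(=S)N/N=C\c2ccc([N+](=O)[O-])cc2)CC1` — 20800 nM

Within the data shown here, in a functional assay on UACC-62 cells (Homo sapiens) for cytotoxicity, read by sulforhodamine B assay (a lower number here means a stronger inhibitor of growth, a higher number a weaker inhibitor of growth), compound 2 gives the higher of the two numbers, the weaker inhibitor of growth, and its only neighbour is compound 1 at a 2.7-fold higher number from compound 1 to compound 2 (0.42 log units; beyond the scatter). Compound 3 `CC1=CC[C@@H]([C@@](C)(O)CCCC(C)(C)NC(=S)N/N=C\c2ccccc2Cl)CC1` differs from compound 2 by 2-chlorophenyl in place of 4-nitrophenyl on a carbon with a double bond to nitrogen. No measured step covers an exchange of this kind; the single step shown only moves the nitro group on the ring, and it is modest. The step from compound 2 to compound 3 is therefore expected to be small, estimated at a 1.7-fold lower number from compound 2 to compound 3 (0.24 log units; within the scatter). Compound 3 is estimated at 12000 nM, within a range from 4000 nM to 36000 nM.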

Compound 3, concentration for 50% growth inhibition: 53300 nM
The estimate for compound 3 lay 4.4-fold (0.65 log units) below the measured number, and the stated range ends below it.
By their numbers in this assay, from the lowest: compound 1; then compound 2; then compound 3.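

In this assay, 2-chlorophenyl in place of 4-nitrophenyl on a carbon with a double bond to nitrogen gives a further loss of growth inhibition (a 2.6-fold higher number from compound 2 to compound 3 (0.41 log units; beyond the scatter)), and in place of 3-nitrophenyl a larger one (a 6.8-fold higher number from compound 1 to compound 3 (0.83 log units; beyond the scatter)). This position therefore responds to exchanging the whole substituted ring as well as to moving the nitro group, and compound 3 is the weakest of the three, with both its steps beyond the scatter. Nothing available here bears on the cause of these steps. Still open, going by these compounds, is how an unsubstituted phenyl, 4-chlorophenyl or a pyridine ring would behave at this position.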